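Swapping 4-fluorophenyl for 2,6-dichlorophenyl in the series

The source may hold more compounds than are shown below. What is called first, only, known or untested is meant among the compounds shown, and "the series" means these compounds.

In a physicochemical assay for lipophilicity (a higher number here means a more lipophilic compound, a lower number a more polar compound), compound 1 `C[C@H]1CC[C@@H]2[C@@H](OC(=O)[C@]23CC(c2ccc(O)cc2)=NO3)[C@]2(C)C(=O)C=C[C@@]12O` gives 0.932 and compound 2 `C[C@H]1CC[C@@H]2[C@@H](OC(=O)[C@]23CC(c2ccccc2Cl)=NO3)[C@]2(C)C(=O)C=C[C@@]12O` gives 2.09 on the same scale. Compound 3 `C[C@H]1CC[C@@H]2[C@@H](OC(=O)[C@]23CC(c2ccc(F)cc2)N(c2ccccc2)O3)[C@]2(C)C(=O)C=C[C@@]12O` gives 3.35 as the highest of the three numbers, and its gaps to both of the others lie beyond the scatter.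

Compound 4 `C[C@H]1CC[C@@H]2[C@@H](OC(=O)[C@]23CC(c2c(Cl)cccc2Cl)N(c2ccccc2)O3)[C@]2(C)C(=O)C=C[C@@]12O` carries 2,6-dichlorophenyl in place of 4-fluorophenyl on a saturated ring carbon, next to the ring nitrogen. The counted difference is 2,6-dichlorophenyl in place of 4-fluorophenyl on a saturated ring carbon in full.

Among the measured compounds shown here, one measured step bears on this change: a number 1.16 log units higher from compound 1 to compound 2 (beyond the scatter) when 2-chlorophenyl replaces 4-hydroxyphenyl, a large step beyond the scatter. It is only a loose guide, since the group that leaves is different and the carbon carrying it has a double bond to nitrogen. For the measured compounds named here, no measured step starts from 4-fluorophenyl.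

A rise beyond the scatter is expected, smaller than that large step, with an estimated step of a number 0.65 log units higher from compound 3 to compound 4 (beyond the scatter) in this assay for this change. Compound 4 is estimated at 4 with an expected range from 3.5 to 4.6 for repeat measurements.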

Compound 4, partition coefficient: 4.45
Estimate against measurement, compound 4: 0.45 log units below, and the stated range covers the measured number.
By their numbers in this assay, from the lowest: compound 1; then compound 2; then compound 3; then compound 4.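

Working notes: in this assay, 2,6-dichlorophenyl in place of 4-fluorophenyl on a saturated ring carbon of the five-membered ring gives a number 1.10 log units higher from compound 3 to compound 4 (beyond the scatter), the first step in the series read at this position. Among the compounds shown here, the only earlier step, a number 1.16 log units higher from compound 1 to compound 2 (beyond the scatter), lay on a carbon with a double bond to nitrogen and also brought in a chlorinated phenyl, so a large rise is now seen at both carbons, though with different groups leaving. No measurement in hand accounts for the size of the new step.

Still open is how this step divides between the loss of 4-fluorophenyl and the entry of each chlorine, since a single chlorine at this carbon does not appear among the compounds shown. Also open, on these data alone, is where the number would fall with an amine or a carboxylic acid on the phenyl at this carbon, or with a change to the phenyl group on the ring nitrogen.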